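Sulfonate ester series: 3-fluorophenyl to 4-methoxyphenyl

This account rests on a few compounds, and the source may have more. Where it says the series, first, only, none or still open, it means among the compounds named here.

- compound 1 `CN1CCN(c2ccc(S(=O)(=O)Oc3cccc(F)c3)cc2)C1=O` gives > 100000 nM as a limit
- compound 2 `CCN1CCN(c2ccc(S(=O)(=O)Oc3cccc(F)c3)cc2)C1=O` gives > 100000 nM as a limit

In a functional assay on MCF7 cells (Homo sapiens) for antiproliferative activity, read by sulforhodamine B assay, with a stated time of 48 h (on this read-out lower numbers stand for stronger inhibition and higher numbers for weaker inhibition), compound 2 gives > 100000 nM as a limit. Both compounds are described by the limit of > 100000 nM in this assay, at which 2 of the 2 values shown sit, and nothing finer. The step to compound 3 `CCN1CCN(c2ccc(S(=O)(=O)Oc3ccc(OC)cc3)cc2)C1=O` puts 4-methoxyphenyl in place of 3-fluorophenyl on an oxygen, counted as 4-methoxyphenyl in place of 3-fluorophenyl on an oxygen in full. Going by the values given here, the only measured step is a step that the two limits leave unreadable from compound 1 to compound 2 and it leaves that group untouched, so no size carries over. The expected change is an at least 5.0-fold lower number from compound 2 to compound 3 (0.69 log units; beyond the scatter) towards stronger inhibition, with a real chance of compound 3 staying at the limit. Compound 3 is estimated at 20000 nM with an expected range from 1000 nM to 100000 nM in this series.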

Compound 3, half-maximal inhibitory concentration: > 100000 nM
Compound 3: a limit, no number; the forecaster's own chance of this, stated with the estimate: 45%; middle value at least 5.0-fold (0.69 log units) from the limit.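

Going by these compounds alone, compound 3 gives > 100000 nM as a limit and not a number, so no step from compound 2 to compound 3 can be read. The compounds shown leave open how 3-fluorophenyl and 4-methoxyphenyl on that oxygen rank, as all rest at one value: the limit of > 100000 nM in this assay, at which 3 of the 3 values shown sit.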